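A few compounds are considered here, and "the series" means these few. Any claim that something is new, unique, unknown or untested is made for them only; others in the source may bear on it.

Series notes. Compound 1 `CC(C)CN(c1ccnc(Nc2ccc(C#N)cc2)n1)c1c(F)cc(-c2ccc(C#N)cc2)cc1F` and compound 2 `N#Cc1ccc(Nc2nccc(N(CCCF)c3c(F)cc(-c4ccc(C#N)cc4)cc3F)n2)cc1` share one core and differ only at the saturated chain on the ring nitrogen. In an ADME assay on MT4 cells (Homo sapiens) for cytotoxicity, read by MTT assay, with a stated time of 5 days (a lower number here means that less compound is tolerated, a higher number that more compound is tolerated), compound 1 gives 241000 nM, and in this assay compound 2 gives 241000 nM. Going by the values given here, the step of no change at the digits printed from compound 1 to compound 2 (within the scatter) is the only one measured in this pair, and it shows that exchanging the chain on that nitrogen left the read-out where it was. Compound 2 therefore stands level with compound 1 on the numbers shown, with no step between them that goes beyond the scatter.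

Compound 3 `CCS(=O)(=O)N(c1ccnc(Nc2ccc(C#N)cc2)n1)c1c(F)cc(-c2ccc(C#N)cc2)cc1F` is the next member to be run in this assay. Its difference from compound 2 is ethylsulfonyl in place of 3-fluoropropyl on a nitrogen on an aromatic ring. Among the compounds with values here, the one step that bears on this position, no change at the digits printed from compound 1 to compound 2 (within the scatter), was flat, but it exchanged one saturated chain for another, whereas here a chain leaves and a sulfonyl group enters, so the precedent is only partial. With nothing in the series pointing to a change, the working expectation for compound 3 is a step of a 1.2-fold lower number from compound 2 to compound 3 (0.08 log units; within the scatter), that is, no move beyond the scatter. The estimate for compound 3 is 200000 nM, with a range from 80000 nM to 300000 nM.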

Compound 3, half-maximal cytotoxic concentration: > 125000 nM
Compound 3 ended at the assay's limit; the forecaster's own chance of this, stated with the estimate: 40%; the middle value does not contradict the limit.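

In this assay compound 3 gives > 125000 nM as a limit of the assay and not a number. Going by these compounds alone, no step from compound 1 or compound 2 to compound 3 can therefore be read. The compounds shown leave open whether ethylsulfonyl on that nitrogen, in place of a saturated chain, shifts the read-out at all.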